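The source may hold more compounds than are shown below. What is called first, only, known or untested is meant among the compounds shown, and "the series" means these compounds.

The three compounds measured so far:

Compound 1, `CC(=O)c1cccc(NC(=O)C2CCCN(C(=O)c3cc(C(F)(F)F)cc(C(F)(F)F)c3)C2)c1`, gives 0% in an ADME assay on PC-3 cells (Homo sapiens) for cytotoxicity, read by WST assay, tested at 100 uM; on this read-out lower numbers stand for less inhibition and higher numbers for more inhibition at the one concentration tested (going by the name of the read-out).
Compound 2, `COc1cccc(C(=O)N2CCCC(C(=O)Nc3ccc(Cl)cc3)C2)c1`, gives 0% in this assay.
Compound 3, `Cn1cnnc1-c1cccc(NC(=O)C2CCCN(C(=O)c3cc(C(F)(F)F)cc(C(F)(F)F)c3)C2)c1`, gives 0% in this assay.

Compound 2 stands level with compound 1 and compound 3 at the digits shown; none of the three inhibits the cells to a measurable degree at the single concentration tested. Going by the values given here, the only step measured within this set is the one from compound 1 to compound 3, no change at the digits printed from compound 1 to compound 3 (within the scatter), where one group on an aromatic carbon was exchanged for another without any change in the read-out.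

The next compound, compound 4, `CC(=O)Nc1cccc(C(=O)N2CCCC(C(=O)Nc3ccc(Cl)cc3)C2)c1`, differs from compound 2 in one place: acetamido in place of methoxy on an aromatic carbon. Among the compounds with values here, no measured step involves an acetamido or a methoxy group, so none bears directly on this change. What the data do show is that a swap of a whole group on an aromatic carbon left the read-out unchanged, and that all three compounds sit at the same floor. On that basis no step beyond the scatter is expected in this assay.

For compound 4 the expected value is 0%, within a range from 0% to 10%, which means an expected step of no change at the digits printed from compound 2 to compound 4 (within the scatter).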

Compound 4, a percentage reported as inhibition, at one concentration (the size of the read-out at that concentration, not a potency): 4%
Estimate against measurement, compound 4: 4 percentage points below; the range from low to high includes it.
By their numbers in this assay, from the lowest: compounds 1, 2, 3 and 4 (each within the scatter of the next).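

Going by these compounds alone, on the aromatic carbon meta to a large group, acetamido in place of methoxy gives a number 4 percentage points higher from compound 2 to compound 4 (within the scatter) in this assay, and this is the first measured change at this position. Acetamido is the larger of the two groups and brings a hydrogen-bond donor that methoxy lacks, yet the read-out stays within the scatter, so this exchange joins the step with no change at the digits printed from compound 1 to compound 3 (within the scatter) as a second swap on an aromatic carbon that shows no clear effect in a different pair of compounds. No measurement shown here gives a reason for this outcome.

From the compounds shown here alone, whether an amine or a carboxylic acid on this aromatic carbon, or a longer chain in place of the acetyl part of the acetamido group, would carry the read-out beyond the scatter remains open. Since each of the four compounds lies within the scatter of the next in this assay, these compounds also leave open which part of the structure, if any, can change the read-out at the one concentration tested.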